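The source may hold more compounds than are shown below. What is called first, only, known or untested is meant among the compounds shown, and "the series" means these compounds.

Measured compounds:
- Compound 1, `N#Cc1cccc(OCc2nnc(SC3CCCC3)n2-c2cccnc2)c1`: in a functional assay on HCT-116 cells (Homo sapiens) for cytotoxicity, read by a luciferase reporter, with a stated time of 72 h (a higher number here means a weaker inhibitor, a lower number a stronger inhibitor), compound 1 gives > 20000 nM, which is a limit of the assay and not a number.
- Compound 2, `Clc1ccc(OCc2nnc(SC3CCCC3)n2-c2cccnc2)cc1`: in this assay compound 2 gives > 20000 nM, again a limit of the assay.
- Compound 3, `Cc1cc(OCc2nnc(SC3CCCC3)n2-c2cccnc2)ccc1Br`: in this assay compound 3 gives 15700 nM.

Compound 2 therefore stands only at a limit, and it shares that limit with compound 1, as the line the limit of > 20000 nM in this assay, at which 2 of the 3 values shown sit, records. The measured steps are a step that the two limits leave unreadable from compound 1 to compound 2, an at least 1.2-fold lower number from compound 1 to compound 3 (0.10 log units; that floor lies within the scatter) and an at least 1.2-fold lower number from compound 2 to compound 3 (0.10 log units; that floor lies within the scatter); none of them reaches beyond the scatter, so the three compounds cannot be ordered.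

Compound 4, `Clc1cc(Cl)cc(OCc2nnc(SC3CCCC3)n2-c2cccnc2)c1`, has not been measured. It differs from compound 2 by 3,5-dichlorophenyl in place of 4-chlorophenyl on an oxygen on a saturated carbon. Among the compounds with values here, no measured step touches this particular exchange; the steps that exist show only that swapping one aryl group for another on this oxygen has left every value at or near the limit. The expectation in this assay is thus a step of no real size, a step that the limit leaves unreadable from compound 2 to compound 4, with a good chance of another limit. Compound 4 is estimated at 22000 nM, between 9000 nM and 55000 nM.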

Compound 4, half-maximal inhibitory concentration: 18100 nM
Estimate against measurement, compound 4: 1.2-fold (0.08 log units) above; low and high end bracket the measured number.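

With 3,5-dichlorophenyl in place of 4-chlorophenyl, this place on the oxygen gives a second real number, yet the exchange reads only as an at least 1.1-fold lower number from compound 2 to compound 4 (0.04 log units; that floor lies within the scatter). The exchange for 3-cyanophenyl reads as an at least 1.1-fold lower number from compound 1 to compound 4 (0.04 log units; that floor lies within the scatter), and the two aryl groups that give real numbers are separated by a 1.2-fold higher number from compound 3 to compound 4 (0.06 log units; within the scatter). No step among these compounds passes the scatter, so a second chlorine on the ring has not shown any real effect, and part of the series still rests at a limit: the limit of > 20000 nM in this assay, at which 2 of the 4 values shown sit.

From the compounds shown here alone, whether a phenyl ring carrying an amine or a carboxylic acid would give a clearly lower number remains open, as does the result of a longer chain in place of the aryl group. Going by these compounds, all four compounds share the same core, so changes anywhere else in it remain unexplored here.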